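Swapping the amide aryl group: from methyl to methoxy

The source may report more compounds than this note shows. Statements on the series, on what has been measured and on what is new or still open speak of the compounds shown alone.

Of the compounds shown here, three sharing one core have been measured in a functional assay on A549 cells (Homo sapiens) for antiproliferative activity, read by CCK-8 assay, with a stated time of 72 h; on this read-out higher numbers stand for weaker inhibition and lower numbers for stronger inhibition. Compound 1 `O=C(Nc1cccc(-c2oc3cc(-c4ccc(F)cc4)ccc3c(=O)c2O)c1)c1ccc(F)cc1` gives 6930 nM. Compound 2 `O=C(Nc1cccc(-c2oc3cc(-c4ccc(F)cc4)ccc3c(=O)c2O)c1)c1ccc(F)cc1F` gives 20500 nM, and compound 3 `Cc1ccccc1C(=O)Nc1cccc(-c2oc3cc(-c4ccc(F)cc4)ccc3c(=O)c2O)c1` gives 17600 nM. Among these numbers compound 3 stands second highest: the step of a 2.5-fold higher number from compound 1 to compound 3 (0.40 log units; beyond the scatter) is beyond the scatter, whereas the step of a 1.2-fold lower number from compound 2 to compound 3 (0.07 log units; within the scatter) is not, so compounds 2 and 3 cannot be told apart. The change to compound 4 `COc1cccc(C(=O)Nc2cccc(-c3oc4cc(-c5ccc(F)cc5)ccc4c(=O)c3O)c2)c1` is 3-methoxyphenyl in place of 2-methylphenyl on a carbonyl carbon. Among the measured compounds shown here, no measured step tries this exact replacement. The nearest evidence is the step of a 2.5-fold higher number from compound 1 to compound 3 (0.40 log units; beyond the scatter) and the step of a 3.0-fold higher number from compound 1 to compound 2 (0.47 log units; beyond the scatter), both showing that moving away from the amide aryl group of compound 1 gave modestly higher numbers, while the step of a 1.2-fold lower number from compound 2 to compound 3 (0.07 log units; within the scatter) shows two such variants landing together. On this basis compound 4 is expected to stay close to compound 3, with an expected step of a 1.2-fold lower number from compound 3 to compound 4 (0.07 log units; within the scatter) that need not exceed the scatter. The estimate for compound 4 is therefore 15000 nM, within a range of 6000 nM to 40000 nM.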

Compound 4, half-maximal inhibitory concentration: 10800 nM
Compound 4: the middle estimate sits 1.4-fold (0.14 log units) above what was measured; measured number inside the range.
By their numbers in this assay, from the lowest: compounds 1, 4, 3 and 2 (each within the scatter of the next, the first and the last beyond it).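

In this assay, 3-methoxyphenyl on the carbonyl carbon adds an oxygen and a hydrogen-bond acceptor, yet all three steps to compound 4 stay within the scatter (a 1.6-fold lower number from compound 3 to compound 4 (0.21 log units; within the scatter); a 1.9-fold lower number from compound 2 to compound 4 (0.28 log units; within the scatter); a 1.6-fold higher number from compound 1 to compound 4 (0.19 log units; within the scatter)). Compound 4 therefore cannot be told apart from any of the other three compounds, even though compounds 2 and 3 each differ from compound 1 by more than the scatter. So this amide aryl group can be changed without a clear loss relative to compound 1, but nothing measured here gives a reason for that.

The step from 2-methylphenyl to 3-methoxyphenyl changes both the group and where it sits on the ring, so the two changes cannot be separated. On these data alone, it also stays open how a nitrile or a carboxylic acid on this ring, or an amine or a longer chain in place of the ring, would behave.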